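Changing the pyridine substituent on a urea-type stomach inhibitor

The source may report more compounds than this note shows. Statements on the series, on what has been measured and on what is new or still open speak of the compounds shown alone.

Measured so far:
compound 1, `Cc1cc(C)nc(N(CCN(C)C)C(=O)N(C)C)c1`, 58%
compound 2, `CCCN(CCC)CCN(C(=O)N(C)C)c1cc(C)cc(C)n1`, 22%
compound 3, `Cc1ccc(N(CCN(C(C)C)C(C)C)C(=O)N(C)C)nc1`, 19%

All three were tested in a functional assay on the whole organism (stomach) for inhibition, with Canis familiaris (Canis lupus familiaris) as the target, at a dose of 20 mg/kg by the oral route; a higher number here means a stronger effect of the compound at the dose given, a lower number a weaker effect. Compound 3 sits at the lower end of the three numbers: compound 2 lies within the scatter of it, so the two cannot be told apart, while compound 1 stands well above it, beyond the scatter. Within the data shown here, the one step measured between two compounds that differ in a single place, a number 36 percentage points lower from compound 1 to compound 2 (beyond the scatter), concerns the amine at the end of the chain, not the aromatic ring.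

Compound 4, `CC(C)N(CCN(C(=O)N(C)C)c1cccc(Cl)n1)C(C)C`, has not been measured. It differs from compound 3 in one place: 6-chloropyridin-2-yl in place of 5-methylpyridin-2-yl on an amide-type nitrogen. Among the measured compounds shown here, no measured step touches this ring, so the data give no guide to the direction or size of the step in this assay. Compound 2 and compound 3 carry different amines and different rings, and their values lie within the scatter of each other, which hints that a ring change need not move the number far.

For the measured compounds named here, with no relevant step to lean on, the step of a number 3 percentage points higher from compound 3 to compound 4 (within the scatter) is expected to stay within the scatter. Compound 4 is therefore estimated at 22%, with a range from 5% to 45%.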

Compound 4, a percentage reported as inhibition, in the whole organism at one dose (the size of the read-out at that dose, not a potency): 78%
Estimate against measurement, compound 4: 56 percentage points below, and the stated range ends below it.
By their numbers in this assay, from the lowest: compounds 3 and 2 (each within the scatter of the next); then compound 1; then compound 4.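

In this assay, putting 6-chloropyridin-2-yl in place of 5-methylpyridin-2-yl on the amide-type nitrogen gives a number 59 percentage points higher from compound 3 to compound 4 (beyond the scatter), so the substituent on this ring can have a large effect on the result at this dose. The ring is therefore a second place, besides the amine at the end of the chain, where a single change produces a large step, as seen in a number 36 percentage points lower from compound 1 to compound 2 (beyond the scatter). The two ring groups match in heavy atoms, ring type, hydrogen-bond donors, hydrogen-bond acceptors and net charge, so those counts do not separate them, and no measurement on these compounds accounts for the step.

This change alters both the substituent and its place on the ring, so the compounds shown leave open which of the two matters, a question that 6-methylpyridin-2-yl or 5-chloropyridin-2-yl would help to settle. Also open, from the compounds shown here alone, is whether 6-chloropyridin-2-yl would have a similar effect alongside the dimethylamino group of compound 1, and whether 6-bromopyridin-2-yl or 6-methoxypyridin-2-yl could stand in for it.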